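Aryl substitution and solubility in the ester series

The compounds below may be only part of what the source reports. "The series", "measured", "known", "first", "only" and "open" are said of these compounds alone.

Measured so far:
compound 1, `CCOC(=O)c1c(-c2ccc(OC)cc2)[nH]c2cccc(OC)c2c1=O` — > 100000 nM
compound 2, `CCOC(=O)c1c(-c2ccc(C(F)(F)F)cc2)[nH]c2cc(OC)ccc2c1=O` — 8000 nM

In a physicochemical assay for solubility, in phosphate buffer, at pH 7.4 (a higher number here means a more soluble compound, a lower number a less soluble compound), compound 1 gives only a limit, > 100000 nM, not a number. This is the limit of > 100000 nM in this assay, at which 1 of the 2 values shown sits, so the true solubility of compound 1 is not pinned down; it stands at the top of what this assay reports. Compound 2 gives 8000 nM in this assay. Within the data shown here, compounds 1 and 2 differ in more than one place, so no single step is drawn between them; their two values alone are what is known.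

Compound 3, `CCOC(=O)c1c(-c2cccc(F)c2)[nH]c2cccc(OC)c2c1=O`, differs from compound 1 in one place: 3-fluorophenyl in place of 4-methoxyphenyl on an aromatic carbon. Among the measured compounds shown here, no measured pair shows this change, so its size rests on expectation only. The step of an at least 3.3-fold lower number from compound 1 to compound 3 (0.52 log units; beyond the scatter) is expected to run toward lower solubility and to exceed the scatter. Compound 3 is expected to give about 30000 nM, within 8000 nM to 100000 nM.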

Compound 3, solubility: > 100000 nM
Compound 3: only a limit was reported (the forecaster's own chance of this, stated with the estimate: 30%); middle value at least 3.3-fold (0.52 log units) away from the limit.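

In this assay compound 3 gives > 100000 nM as a limit, not a number. Compound 1 also stands at a limit, so no step can be read between compound 1 and compound 3: the limit of > 100000 nM in this assay, at which 2 of the 3 values shown sit. On these data alone, how far either compound lies past that limit stays open.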